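Weak Inhibitors of Maltase-Glucoamylase: Swapping the Aryl Terminus

This account rests on a few compounds, and the source may have more. Where it says the series, first, only, none or still open, it means among the compounds named here.

Three compounds sharing one core were tested in an assay on isolated protein for inhibition of Maltase-glucoamylase (Homo sapiens), with a stated time of 15 min; on this read-out higher numbers stand for weaker inhibition and lower numbers for stronger inhibition. Compound 1 `O=C(N/N=C/c1cccnc1)c1ccc(-c2nc3ccccc3s2)cc1` carries a pyridin-3-yl group at the end of its hydrazone chain; in this assay compound 1 gives "not active" (no number reported), so no number marks where it stands. Compound 3 `COC(=O)c1ccc(/C=N/NC(=O)c2ccc(-c3nc4ccccc4s3)cc2)cc1` is the same kind of case: in this assay compound 3 gives "not active" (no number reported). Only compound 2 `O=C(N/N=C/c1cccs1)c1ccc(-c2nc3ccccc3s2)cc1` yields a figure, and in this assay compound 2 gives 8480 nM, which is weak inhibition for a half-maximal inhibitory concentration. Within the data shown here, no step between two measured compounds is available, so nothing can be said about the size of any single change.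

Compound 4 `COc1cc(/C=N/NC(=O)c2ccc(-c3nc4ccccc4s3)cc2)cc(OC)c1` is the next candidate. It differs from compound 1 in one place: 3,5-dimethoxyphenyl in place of pyridin-3-yl on a carbon with a double bond to nitrogen. As far as these compounds go, whether the loss of the pyridin-3-yl nitrogen and the arrival of two methoxy groups on a carbon-only ring will move the read-out at all is unknown from these data alone. Given that compound 2 gives 8480 nM and the other two report no number, compound 4 is expected to land around 15000 nM, with a range from 5000 nM to 60000 nM.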

Compound 4, half-maximal inhibitory concentration: 16200 nM
Estimate against measurement, compound 4: 1.1-fold (0.03 log units) below; the measured number falls inside the stated range.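

In this assay, putting 3,5-dimethoxyphenyl in place of thiophen-2-yl on a carbon with a double bond to nitrogen gives a 1.9-fold higher number from compound 2 to compound 4 (0.28 log units; within the scatter) and so the two end groups cannot be told apart on this read-out. A measurable value is therefore not tied to thiophen-2-yl, yet a carbon-only ring does not ensure one, since compound 3 with its methyl ester gives "not active" (no number reported) in this assay. The steps involving compound 1 or compound 3 cannot be read as sizes, and nothing measured here explains the results.

As far as these compounds go, it remains open whether an amine or a carboxylic acid on the carbon-only ring would give a number. Also open, from the compounds shown here alone, is whether a single methoxy group would serve as well as the two in compound 4.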